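A few compounds are considered here, and "the series" means these few. Any claim that something is new, unique, unknown or untested is made for them only; others in the source may bear on it.

Compound 1 `COc1ccc(NC(=O)[C@@H]2CC=C(CCC=C(C)C)C[C@H]2c2ccccc2)cc1` was tested in an assay on isolated protein for inhibition of Apoptosis regulator Bcl-2 (Homo sapiens), read by fluorescence polarization, with stated times of 5 min and 10 min; on this read-out higher numbers stand for weaker inhibition and lower numbers for stronger inhibition. In this assay compound 1 gives only a limit, > 23000 nM, and no number. Compound 2 `COC(=O)c1ccc(NC(=O)[C@H]2CC=C(CCC=C(C)C)C[C@@H]2c2ccccc2)cc1` was tested in this assay as well. In this assay compound 2 likewise reaches only a limit, > 23000 nM. Among the compounds with values here, both values therefore sit at the same boundary, (the limit of > 23000 nM in this assay, at which 2 of the 2 values shown sit), so no step between them can be read. Compound 3 `CC(C)=CCCC1=CC[C@@H](C(=O)N(C)O)[C@H](c2ccccc2)C1` differs from compound 1 by hydroxy(methyl)amino in place of (4-methoxyphenyl)amino on a carbonyl carbon. The step from compound 1 to compound 3 is expected to be a step that the limit leaves unreadable from compound 1 to compound 3, with no change beyond the scatter foreseen. For compound 3 the estimate in this assay is 30000 nM, expected between 6000 nM and 150000 nM.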

Compound 3, inhibition constant: 2300 nM
Compound 3: middle estimate off by 13-fold (1.12 log units), on the high side; the measured number lies below the stated range.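

In this assay, within the data shown here, placing hydroxy(methyl)amino on the carbonyl carbon gives an at least 10-fold lower number from compound 1 to compound 3 (1.00 log units; beyond the scatter), so this place on the shared core can carry a measurable inhibition constant, which the earlier compounds did not show. The size of the step is only a lower bound, because compound 1 gives a limit and no number: the limit of > 23000 nM in this assay, at which 2 of the 3 values shown sit.

The change removes the aromatic ring and brings in the hydroxy and methyl groups together, so the compounds shown do not separate their contributions. As far as these compounds go, it remains open how methylamino, hydroxyamino or a carboxylic acid would behave at this carbonyl carbon.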